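Series notes: ethynyl in place of pyridin-2-yl

A few compounds are considered here, and "the series" means these few. Any claim that something is new, unique, unknown or untested is made for them only; others in the source may bear on it.

Measured in a functional assay on NFS-60 cells (Mus musculus) for inhibition, with a stated time of 72 h; on this read-out lower numbers stand for stronger inhibition of growth and higher numbers for weaker inhibition of growth:
compound 1, `COc1ccc(Cn2nc(Br)c3c(NC(=O)c4csc5c(N)ncnc45)cccc32)cc1`, gives 2390 nM
compound 2, `Nc1ncnc2c(C(=O)Nc3cccc4c3c(Br)nn4Cc3ccccn3)csc12`, gives 2500 nM
compound 3, `Nc1ncnc2c(C(=O)Nc3cccc4c3c(Br)nn4Cc3ccncc3)csc12`, gives 135 nM

Compound 2 carries the highest number of the three, but the step there is only a 1.0-fold higher number from compound 1 to compound 2 (0.02 log units; within the scatter), which is within the scatter, so compound 1 and compound 2 cannot be ordered. Against compound 3 the gap is a 19-fold lower number from compound 2 to compound 3 (1.27 log units; beyond the scatter), a large step.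

Compound 4, `C#CCn1nc(Br)c2c(NC(=O)c3csc4c(N)ncnc34)cccc21`, differs from compound 2 by ethynyl in place of pyridin-2-yl on a saturated chain carbon bound to an aromatic nitrogen. Going by the values given here, two measured steps touch the same place: from compound 1 to compound 2 the change gave a 1.0-fold higher number from compound 1 to compound 2 (0.02 log units; within the scatter), and from compound 2 to compound 3 it gave a 19-fold lower number from compound 2 to compound 3 (1.27 log units; beyond the scatter). Both exchange one six-membered aromatic ring for another; neither replaces the ring with a short chain. The place clearly matters, since one exchange there was large, yet the direction for a ring-to-chain change cannot be read from the series. The step from compound 2 to compound 4 in this assay is therefore expected to be a 1.2-fold higher number from compound 2 to compound 4 (0.08 log units; within the scatter), with a wide range. Compound 4 is estimated to give 3000 nM in this assay, between 700 nM and 13000 nM.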

Compound 4, concentration for 50% growth inhibition: > 10000 nM
Compound 4 gave a limit, no number; the forecaster's own chance of this, stated with the estimate: 10%; middle value at least 3.3-fold (0.52 log units) away from the limit.
By their numbers in this assay, from the lowest: compound 3; then compounds 1 and 2 (each within the scatter of the next). At a limit, above all of these: compound 4.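

In this assay, compound 4 gives a limit and not a number: the limit of > 10000 nM in this assay, at which 1 of the 4 values shown sits. Going by these compounds alone, the earlier steps at this position only exchanged one six-membered aromatic ring for another, and the change from pyridin-2-yl to ethynyl is the first to separate a compound from both compound 1 and compound 2, with an at least 4.0-fold higher number from compound 2 to compound 4 (0.60 log units; beyond the scatter) and an at least 4.1-fold higher number from compound 1 to compound 4 (0.62 log units; beyond the scatter). Against the best ring in the series the step is larger, with an at least 74-fold higher number from compound 3 to compound 4 (1.86 log units; beyond the scatter), so at this place ethynyl matches none of the three aromatic rings shown.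

Going by these compounds, the true size of these steps stays open, since each rests on a limit. On these data alone, whether the loss follows the absence of a ring or the triple bond itself is also open, and a propyl chain or a chain ending in an amine would separate the two.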